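Notes on compound 4: methyl in place of chloro

The source may report more compounds than this note shows. Statements on the series, on what has been measured and on what is new or still open speak of the compounds shown alone.

The series shares one core and varies the group on the carbonyl carbon. Compound 1 `O=C(NC(=S)NNc1ncnc2ccccc12)c1ccccc1F` carries a 2-fluorophenyl group; in a functional assay on CNE-2 cells (Homo sapiens) for cytotoxicity, read by MTT assay, with a stated time of 72 h (a higher number here means a weaker inhibitor, a lower number a stronger inhibitor), compound 1 gives 4610 nM. Compound 2 `O=C(NC(=S)NNc1ncnc2ccccc12)c1ccccc1` has hydrogen in place of that fluoro, and in this assay compound 2 gives 1490 nM. Compound 3 `O=C(NC(=S)NNc1ncnc2ccccc12)c1ccc(Cl)cc1` carries a 4-chlorophenyl group; in this assay compound 3 gives 1530 nM, the second highest of the three numbers, close to compound 2 and well apart from compound 1. The steps of a 3.1-fold lower number from compound 1 to compound 2 (0.49 log units; beyond the scatter) and a 3.0-fold lower number from compound 1 to compound 3 (0.48 log units; beyond the scatter) are both beyond the scatter, whereas the step of a 1.0-fold higher number from compound 2 to compound 3 (0.01 log units; within the scatter) is within it.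

Compound 4 `Cc1ccc(C(=O)NC(=S)NNc2ncnc3ccccc23)cc1` differs from compound 3 by the change (methyl in place of chloro on an aromatic carbon). For the measured compounds named here, the only measured step that bears on this place, a 1.0-fold higher number from compound 2 to compound 3 (0.01 log units; within the scatter), shows that putting chloro there in place of hydrogen left the number essentially unchanged; no compound with methyl at this place has been measured, so the expectation rests on that single step. A step of a 1.0-fold lower number from compound 3 to compound 4 (0.01 log units; within the scatter) is therefore expected in this assay, that is, none beyond the scatter. Compound 4 is expected to give about 1500 nM in this assay, with a range from 700 nM to 3500 nM.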

Compound 4, half-maximal inhibitory concentration: 17200 nM
Compound 4: the middle estimate sits 11-fold (1.06 log units) below what was measured, outside the stated range (above it).
By their numbers in this assay, from the lowest: compounds 2 and 3 (each within the scatter of the next); then compound 1; then compound 4.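

For the compounds shown here, at the position para to a large group, hydrogen and chloro had given numbers within the scatter of each other, so the earlier compounds suggested a tolerant position; methyl breaks that picture in this assay with an 11-fold higher number from compound 3 to compound 4 (1.05 log units; beyond the scatter) and a 12-fold higher number from compound 2 to compound 4 (1.06 log units; beyond the scatter) as its two large steps. The exchange is one heavy atom for one heavy atom, with no ring, donor, acceptor or net charge entering or leaving, so these counts do not separate chloro from methyl, yet the number moves strongly. Compound 4 also passes the earlier weakest member of the series, with a 3.7-fold higher number from compound 1 to compound 4 (0.57 log units; beyond the scatter) on the group at the carbonyl carbon, which makes compound 4 the weakest of the four and 4-methylphenyl a poorer group here than 2-fluorophenyl.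

Open, from the compounds shown here alone, is whether the loss belongs to methyl alone or extends to other groups at this place, such as ethyl, methoxy, trifluoromethyl or an amine, and whether methyl costs as much elsewhere on the ring. Nothing measured here speaks to why methyl and chloro part so widely at this position.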